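Imidazole side-chain variation in a bombesin receptor agonist series

The source may report more compounds than this note shows. Statements on the series, on what has been measured and on what is new or still open speak of the compounds shown alone.

Measured so far:
compound 1 `CCCCc1cnc(C(CC)Cc2ccc(-c3ccccc3C(=O)O)cc2)[nH]1` gives 2720 nM
compound 2 `CC(C)(C)CCc1cnc(CCc2ccc(-c3ccccc3C(=O)O)cc2)[nH]1` gives 39 nM

Among the measured compounds shown here, in an in vitro functional assay on cells for agonist activity at Bombesin receptor subtype-3 (Homo sapiens), read by luminescence and calcium flux (on this read-out lower numbers stand for an effect already at smaller amounts and higher numbers for an effect only at larger amounts of compound), compound 2 stands lowest of the two numbers, and compound 1 gives the only other value, a number beyond the scatter above it. Compound 3 `COc1cccc(Cc2cnc(CCc3ccc(-c4ccccc4C(=O)O)cc3)[nH]2)c1` has not been measured. It differs from compound 2 by 3-methoxyphenyl in place of neopentyl on a saturated chain carbon bound to an aromatic carbon. For the measured compounds named here, no measured pair shows this change, so the size of the step is open. Compound 3 is expected to show a 3.1-fold higher number from compound 2 to compound 3 (0.49 log units; beyond the scatter), a loss of moderate size. For compound 3 the estimate is 120 nM, with a range from 25 nM to 700 nM.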

Compound 3, half-maximal effective concentration: 4120 nM
Beside the measured number, compound 3's estimate is 34-fold (1.54 log units) below it, and the stated range ends below it.
By their numbers in this assay, from the lowest: compound 2; then compounds 1 and 3 (each within the scatter of the next).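

In this assay the swap of neopentyl for 3-methoxyphenyl on a saturated chain carbon bound to an aromatic carbon gives a 110-fold higher number from compound 2 to compound 3 (2.02 log units; beyond the scatter) and is a large loss. Among the compounds shown here, compound 1 and compound 2 differ in more than one place, so this is the first step that reads this position alone, and it shows that the value depends strongly on the group held there. No measurement shown here accounts for the size of this step. On these data alone, whether the loss follows the aromatic ring or the methoxy group stays open. An unsubstituted phenyl, a longer alkyl chain or an amine at this place would help separate the two.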